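Pentyl to Cyclopentylamino on the Amide Carbonyl

The source may hold more compounds than are shown below. What is called first, only, known or untested is meant among the compounds shown, and "the series" means these compounds.

Compound 1 `CCCCCC(=O)Nc1ccc(S(=O)(=O)Oc2ccccc2C(C)C)cc1`: 5300 nM
Compound 2 `CCCCCC(=O)Nc1ccc(S(=O)(=O)Oc2ccccc2I)cc1`: 10000 nM
Compound 3 `O=C(Nc1ccc(S(=O)(=O)Oc2ccccc2I)cc1)NC1CC1`: 7400 nM

All three compounds were tested in a functional assay on MCF7 cells (Homo sapiens) for antiproliferative activity, read by sulforhodamine B assay, with a stated time of 48 h; on this read-out higher numbers stand for weaker inhibition and lower numbers for stronger inhibition. Compound 1 has the smallest number of the three, yet neither of the other two is separated from it by more than the usual scatter, so the set gives no real ranking. The swap of isopropyl for iodo is seen in a 1.9-fold higher number from compound 1 to compound 2 (0.28 log units; within the scatter), and the exchange of the amide chain for a urea is seen in a 1.4-fold lower number from compound 2 to compound 3 (0.13 log units; within the scatter); both are movements inside the scatter.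

The unmeasured compound 4 `CC(C)c1ccccc1OS(=O)(=O)c1ccc(NC(=O)NC2CCCC2)cc1` differs from compound 1 in one place: cyclopentylamino in place of pentyl on a carbonyl carbon. Going by the values given here, the only measured step that bears on this change is the one from compound 2 to compound 3, where a cyclopropylamino took the place of the pentyl and the number barely moved. That step was made on the iodo-bearing core rather than the isopropyl-bearing one, and the cyclopentylamino group is one ring larger than the cyclopropylamino, so the precedent is close but not exact. Nothing among these three compounds points to a shift beyond the scatter in this assay.

Compound 4 is therefore estimated at 4500 nM, with a range from 2000 nM to 11000 nM, meaning an expected step of a 1.2-fold lower number from compound 1 to compound 4 (0.07 log units; within the scatter).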

Compound 4, half-maximal inhibitory concentration: 6200 nM
Compound 4: the middle estimate sits 1.4-fold (0.14 log units) below what was measured, within the range that was stated.
By their numbers in this assay, from the lowest: compounds 1, 4, 3 and 2 (each within the scatter of the next).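

In this assay, going by these compounds alone, replacing pentyl with cyclopentylamino on the carbonyl carbon gives a 1.2-fold higher number from compound 1 to compound 4 (0.07 log units; within the scatter), so this exchange also stays inside the scatter on the isopropyl-bearing core, whereas the earlier compounds showed it only on the iodo-bearing core, with a 1.4-fold lower number from compound 2 to compound 3 (0.13 log units; within the scatter) for cyclopropylamino. Across these two steps, the amide becomes a urea, a chain without a ring gives way to a ring-bearing group, and a hydrogen-bond donor enters with the added nitrogen, yet neither step gives a readable change in the antiproliferative number. No measurement offered here accounts for this flat response at the position.

The compounds shown leave open whether a markedly different group on this carbonyl carbon, such as a longer chain like octyl, an open-chain diethylamino group or a chain ending in a carboxylic acid, would move the number beyond the scatter. From the compounds shown here alone, it also remains open whether cyclopentylamino and cyclopropylamino would differ from each other on one and the same core.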